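Adding Fluoro to a Benzoyl Ring: Vero Cell Toxicity

A few compounds are considered here, and "the series" means these few. Any claim that something is new, unique, unknown or untested is made for them only; others in the source may bear on it.

Measured so far in a toxicity assay on Vero cells (Chlorocebus sabaeus) for inhibition, read by MTT assay, with a stated time of 48 h; a higher number here means a weaker inhibitor, a lower number a stronger inhibitor:
Compound 1 `O=C(N/N=C/c1c(-c2cc3ccccc3oc2=O)[nH]c2ccccc12)c1ccc(Cl)cc1` gives > 200000 nM, which is a limit of the assay rather than a number.
Compound 2 `O=C(N/N=C/c1c(-c2cc3ccccc3oc2=O)[nH]c2ccccc12)c1cccc(Br)c1` gives > 200000 nM, likewise a limit.
Compound 3 `O=C(N/N=C/c1c(-c2cc3ccc(Br)cc3oc2=O)[nH]c2ccccc12)c1ccc(Cl)cc1` gives 71400 nM.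

Among the measured compounds shown here, compound 3 therefore holds the only actual number in this set; the other two readings sit at the limit of > 200000 nM in this assay, at which 2 of the 3 values shown sit. The step of an at least 2.8-fold lower number from compound 1 to compound 3 (0.44 log units; beyond the scatter) came with bromo in place of hydrogen on an aromatic carbon of the shared core. The step that the two limits leave unreadable from compound 1 to compound 2 cannot be sized, since both ends are limits.

Compound 4 `O=C(N/N=C/c1c(-c2cc3ccc(Br)cc3oc2=O)[nH]c2ccccc12)c1ccc(Cl)cc1F` differs from compound 3 by fluoro in place of hydrogen on an aromatic carbon. For the measured compounds named here, no measured step touches this change: the two steps seen concern bromo on the core and 3-bromophenyl in place of 4-chlorophenyl on a carbonyl carbon, and neither involves fluoro. With nothing pointing to a shift, the expected step in this assay is a 1.0-fold lower number from compound 3 to compound 4 (0.01 log units; within the scatter), within the scatter. Compound 4 is accordingly estimated at 70000 nM, with a range from 30000 nM to 200000 nM.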

Compound 4, half-maximal inhibitory concentration: < 25000 nM
Compound 4 gave a limit, no number; the forecaster's own chance of this, stated with the estimate: 25%; middle value at least 2.8-fold (0.44 log units) away from the limit.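

The reading for compound 4 is a limit of the assay and not a number: the limit of < 25000 nM in this assay, at which 1 of the 4 values shown sits. Even so, the direction is clear: in this assay, going from 4-chlorophenyl to 4-chloro-2-fluorophenyl gives an at least 2.8-fold lower number from compound 3 to compound 4 (0.45 log units; beyond the scatter). Among the compounds shown here, until now, the only readable shift came with bromo on the shared core, and the one change on the carbonyl side could not be read, so this is the first sign that a single fluoro on this outer ring, ortho to a large group, can move the result.

Going by these compounds, the true size of the step stays open, as does whether fluoro would act the same way on a core without bromo, as in compound 1. Also open, on these data alone, is how a methyl group, a methoxy group or an amine would behave at this same place.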